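Swapping a piperazine for a nitroimidazole on a cytotoxicity-clean chain

The compounds below may be only part of what the source reports. "The series", "measured", "known", "first", "only" and "open" are said of these compounds alone.

Of the compounds shown here, three built on one shared core have been tested in an ADME assay on Vero cells (Chlorocebus sabaeus) for cytotoxicity, read by sulforhodamine B assay, with a stated time of 72 h; on this read-out lower numbers stand for stronger inhibition and higher numbers for weaker inhibition. Compound 1 `CN1Cc2ccc(OCCCc3ccccc3)cc2[C@@H](O)C1` carries a benzyl tail on its chain. In this assay compound 1 gives > 50000 nM, a limit of the assay rather than a number. Compound 2 `CN1Cc2ccc(OCCC3CCCCC3)cc2[C@@H](O)C1` has cyclohexyl in place of benzyl. In this assay compound 2 gives > 50000 nM, again a limit. Compound 3 `CN1Cc2ccc(OCCCN3CCNCC3)cc2[C@@H](O)C1` carries piperazin-1-yl in place of phenyl. In this assay compound 3 gives > 100000 nM, also a limit. For the measured compounds named here, with every value sitting at a limit, the limit of > 50000 nM in this assay, at which 2 of the 3 values shown sit, or (the limit of > 100000 nM in this assay, at which 1 of the 3 values shown sits), the steps a step that the two limits leave unreadable from compound 1 to compound 2, a step that the two limits leave unreadable from compound 1 to compound 3 and a step that the two limits leave unreadable from compound 2 to compound 3 cannot be sized, so no measured step gives a readable trend.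

Compound 4 `CN1Cc2ccc(OCCCn3ccnc3[N+](=O)[O-])cc2[C@@H](O)C1` differs from compound 3 by 2-nitro-1H-imidazol-1-yl in place of piperazin-1-yl on a saturated chain carbon, three bonds along the chain from an oxygen on an aromatic ring. Since none of the three steps is readable and compound 3 itself sits at a limit, the step of an at least 1.2-fold lower number from compound 3 to compound 4 (0.09 log units; that floor lies within the scatter) is expected to stay within the scatter. Compound 4 is therefore estimated at 80000 nM, with a range from 30000 nM to 200000 nM, and most likely another limit.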

Compound 4, half-maximal inhibitory concentration: > 50000 nM
Compound 4 ended at the assay's limit (the forecaster's own chance of this, stated with the estimate: 75%); the middle value is on the limit's open side.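

In this assay compound 4 gives > 50000 nM, a limit of the assay and not a number. Its steps from compound 3 and from compound 1 therefore cannot be read. The compounds shown leave open at what concentration, if any, each of them would reach half-maximal inhibition.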